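This account rests on a few compounds, and the source may have more. Where it says the series, first, only, none or still open, it means among the compounds named here.

Compound 1 `Cc1nc(-c2ccc(F)cc2)sc1COc1ccc(OCC(=O)O)c(F)c1`: 112 nM
Compound 2 `Cc1ccc(-c2nc(C)c(COc3ccc(OCC(=O)O)c(F)c3)s2)cc1`: 156 nM
Compound 3 `O=C(O)COc1ccc(OCc2csc(-c3ccccc3)n2)cc1F`: a limit of the assay only, > 10000 nM

In an assay on CHO cells for agonist activity at Free fatty acid receptor 1 (Homo sapiens), read by FLIPR (on this read-out higher numbers stand for an effect only at larger amounts of compound and lower numbers for an effect already at smaller amounts), compound 1 gives 112 nM. The change methyl in place of fluoro on an aromatic carbon brings a 1.4-fold higher number from compound 1 to compound 2 (0.14 log units; within the scatter). Compound 3 reaches only the assay limit, (the limit of > 10000 nM in this assay, at which 1 of the 3 values shown sits). The difference between the core of compound 3 and that of compound 1 is not broken down here. Compound 4 `Cc1cc(OCc2csc(-c3ccccc3)n2)ccc1OCC(=O)O` carries the same kind of change as compound 2, (methyl in place of fluoro on an aromatic carbon), but here the place is ortho to a carboxymethoxy group and meta to a large group, whereas in compound 2 it is para to a large group. Since compound 3 sits at the limit and the earlier step of a 1.4-fold higher number from compound 1 to compound 2 (0.14 log units; within the scatter) was within the scatter, the step that the limit leaves unreadable from compound 3 to compound 4 is expected to be small, and compound 4 is estimated at 15000 nM in this assay.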

Compound 4, half-maximal effective concentration: > 10000 nM
Compound 4 gave a limit, no number; the forecaster's own chance of this, stated with the estimate: 75%; the middle value is on the limit's open side.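

Among the compounds shown here, compound 3 and compound 4 both sit at a limit of this assay rather than at a number, so no step between them can be read. The compounds shown leave open how methyl in place of fluoro acts on the core of compound 3.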